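Swapping a Chlorophenyl Group for a Benzodioxinyl Group

The source may hold more compounds than are shown below. What is called first, only, known or untested is meant among the compounds shown, and "the series" means these compounds.

Of the compounds shown here, two sharing the same core have been measured in a functional assay on MCF7 cells (Homo sapiens) for inhibition, read by MTT assay, with a stated time of 72 h; a higher number here means a weaker inhibitor of growth, a lower number a stronger inhibitor of growth. Compound 1 `O=S(=O)(NCCCNCc1ccccc1Cl)c1cc(C(F)(F)F)cc(C(F)(F)F)c1` gives 8800 nM, the higher of the two numbers. Compound 2 `O=S(=O)(NCCNCc1ccc(-c2ccccc2)cc1)c1cc(C(F)(F)F)cc(C(F)(F)F)c1` gives 1400 nM, a lower number, and the gap between the two lies beyond the usual scatter of this kind of measurement. Within the data shown here, no single-point step between these two measured compounds is described, so their values are noted only as they stand.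

Compound 3 `O=S(=O)(NCCCNCC1COc2ccccc2O1)c1cc(C(F)(F)F)cc(C(F)(F)F)c1` has not yet been measured. It differs from compound 1 in one place: 2,3-dihydro-1,4-benzodioxin-2-yl in place of 2-chlorophenyl on a saturated chain carbon bound to an amine nitrogen. Among the measured compounds shown here, none of the measured compounds shows the effect of such a change, so no direction can be drawn from them. In this assay the expected change is a 1.0-fold higher number from compound 1 to compound 3 (0.01 log units; within the scatter), a step not beyond the scatter. Compound 3 is therefore estimated at 9000 nM, with a likely range from 3000 nM to 27000 nM.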

Compound 3, concentration for 50% growth inhibition: 2500 nM
Compound 3: the middle estimate sits 3.6-fold (0.56 log units) above what was measured; measured number below the stated range.
By their numbers in this assay, from the lowest: compounds 2 and 3 (each within the scatter of the next); then compound 1.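

Among these compounds, on a saturated chain carbon bound to an amine nitrogen, 2,3-dihydro-1,4-benzodioxin-2-yl in place of 2-chlorophenyl gives a 3.5-fold lower number from compound 1 to compound 3 (0.55 log units; beyond the scatter) in this assay, showing that the number responds to a change at this position, which the earlier compounds could not show. The change removes the chlorine and brings in two oxygen atoms, a second ring and two hydrogen-bond acceptors all at once, so this single step cannot assign the shift to any one of these features. No evidence is available to explain the lower number.

Still open, on these data alone, is whether a plain phenyl or a 2-methoxyphenyl group at this place would give a similar number, which would help separate the loss of chlorine from the gain of oxygen. Also open, as far as these compounds go, is whether the step would hold with a longer chain on the shared core.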